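This account rests on a few compounds, and the source may have more. Where it says the series, first, only, none or still open, it means among the compounds named here.

Of the compounds shown here, three that share one core have been tested in an ADME assay on Huh-7 cells (Homo sapiens) for cytotoxicity, read by MTT assay, with a stated time of 72 h; on this read-out higher numbers stand for lower toxicity in this test and lower numbers for higher toxicity in this test. Compound 1, `COc1cc(O)c(C(=O)/C=C/c2ccc(OCc3cn(-c4ccc(F)cc4Cl)nn3)c(OC)c2)c(OC)c1`, gives a reading that is a limit of the test rather than a number, > 100 ug/mL. Compound 2, `COc1cc(O)c(C(=O)/C=C/c2ccc(OCc3cn(-c4ccccc4Cl)nn3)c(OC)c2)c(OC)c1`, likewise gives only a limit, > 100 ug/mL. Compound 3, `COc1cc(O)c(C(=O)/C=C/c2ccc(OCc3cn(-c4ccc(F)c(Cl)c4)nn3)c(OC)c2)c(OC)c1`, also gives only a limit, > 100 ug/mL. Compound 3 therefore stands where every measured compound stands, at the limit of > 100 ug/mL in this assay, at which 3 of the 3 values shown sit. The steps among the measured compounds, a step that the two limits leave unreadable from compound 1 to compound 2, a step that the two limits leave unreadable from compound 1 to compound 3 and a step that the two limits leave unreadable from compound 2 to compound 3, cannot be sized, as both ends of each lie at the limit.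

Compound 4, `COc1cc(O)c(C(=O)/C=C/c2ccc(OCc3cn(-c4ccc(Cl)cc4)nn3)c(OC)c2)c(OC)c1`, differs from compound 3 in one place: 4-chlorophenyl in place of 3-chloro-4-fluorophenyl on an aromatic nitrogen. The three measured steps all concern such an exchange of one halogen-bearing phenyl for another on the same aromatic nitrogen, and none of them moved the reading off the limit. So the step to compound 4 is expected to stay within the scatter, a number no higher from compound 3 to compound 4 (the limit leaves the size open). In this assay compound 4 is estimated at 100 ug/mL, with a range from 50 ug/mL to 200 ug/mL, most likely reported again only as a limit.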

Compound 4, half-maximal cytotoxic concentration: > 100 ug/mL
Compound 4 gave a limit, no number; the forecaster's own chance of this, stated with the estimate: 80%; the middle value sits exactly at the limit.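

Within the data shown here, compound 4 sits with compound 1, compound 2 and compound 3 at the same limit, so no step from any of them to compound 4 can be read in this assay: the limit of > 100 ug/mL in this assay, at which 4 of the 4 values shown sit. The compounds shown leave open how far apart these four truly lie, and whether any phenyl group on the aromatic nitrogen would give a number rather than a limit.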